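The source may hold more compounds than are shown below. What is called first, only, known or untested is meant among the compounds shown, and "the series" means these compounds.

Measured compounds:
- compound 1, `CC(C)(C)N(NC(=O)c1ccccc1)C(=O)c1ccccc1Br`: 170 nM
- compound 2, `CC(C)(C)N(NC(=O)c1ccccc1)C(=O)c1ccccc1I`: 105 nM
- compound 3, `CC(C)(C)N(NC(=O)c1ccccc1Cl)C(=O)c1ccccc1Cl`: 331 nM

All three were tested in an assay on cells for agonist activity at ecdysone receptor (Bombyx mori), read by a luciferase reporter, with a stated time of 24 h; a lower number here means that less compound is needed, a higher number that more compound is needed for the effect. Compound 3 shows the highest number of the three, though its gap to compound 1 stays within the scatter, while its gap to compound 2 is beyond it. Among the compounds with values here, the only single-point step among the measured compounds is a 1.6-fold lower number from compound 1 to compound 2 (0.21 log units; within the scatter), a halogen swap on an aromatic carbon.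

Compound 4, `CCCCCCC(=O)NN(C(=O)c1ccccc1Cl)C(C)(C)C`, has not yet been tested. Its difference from compound 3 is hexyl in place of 2-chlorophenyl on a carbonyl carbon. This is a change of a different kind from the halogen swap: an entire aromatic ring bearing chlorine is exchanged for a six-carbon chain without any ring. Within the data shown here, no measured step touches that kind of exchange, so the measured data give no direct guide to its size. Every measured compound keeps two aromatic rings on the shared core, and compound 4 would be the first to carry only one. With nothing to anchor the change, the expectation is a clearly higher number, carrying wide uncertainty. Compound 4 is therefore estimated at 3000 nM, with a range from 600 nM to 15000 nM, meaning an expected step of a 9.1-fold higher number from compound 3 to compound 4 (0.96 log units; beyond the scatter).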

Compound 4, half-maximal effective concentration: 741 nM
Estimate against measurement, compound 4: 4.0-fold (0.61 log units) above; the range from low to high includes it.
By their numbers in this assay, from the lowest: compounds 2, 1 and 3 (each within the scatter of the next, the first and the last beyond it); then compound 4.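

In this assay, putting hexyl in place of 2-chlorophenyl on a carbonyl carbon whose other neighbours are amide-type nitrogen gives a 2.2-fold higher number from compound 3 to compound 4 (0.35 log units; beyond the scatter), a modest step that lies beyond the scatter. Every earlier compound keeps two aromatic rings, so none of them could show that this place tolerates an open chain with no ring at all: the effect is still reached at a concentration not far removed from that of the ring-bearing parent, although more compound is needed. Nothing measured here bears on the reason for this step, so the rise in the number remains a plain observation without an explanation.

As far as these compounds go, what stays open is how the number depends on the chain itself, since a shorter butyl or a longer octyl chain at this place could give a number on either side of the hexyl result. It is also unknown whether a ring as such matters here, a question that cyclohexyl, a ring of six carbons that is not aromatic, would help to settle.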